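Moving a Methoxy Group Around an Aromatic Ring

This account rests on a few compounds, and the source may have more. Where it says the series, first, only, none or still open, it means among the compounds named here.

Within the data shown here, compound 2 `COc1ccccc1NC1=CC(=O)c2c(nc3n2[C@H]2OC[C@@H](O)[C@H]2OC3)C1=O` is one of two compounds measured in a functional assay on MGC-803 cells (Homo sapiens) for inhibition, read by sulforhodamine B assay (a higher number here means a weaker inhibitor, a lower number a stronger inhibitor), and in this assay compound 2 gives 1670 nM. The other, compound 1 `O=C1C(Nc2ccccc2)=CC(=O)c2c1nc1n2[C@H]2OC[C@@H](O)[C@H]2OC1`, shares the same core and in this assay compound 1 gives 1830 nM. The step from compound 1 to compound 2 is a 1.1-fold lower number from compound 1 to compound 2 (0.04 log units; within the scatter), so neither of the two can be called the stronger inhibitor on these numbers. Compound 3 `COc1cccc(NC2=CC(=O)c3c(nc4n3[C@H]3OC[C@@H](O)[C@H]3OC4)C2=O)c1` has not yet been measured. It differs from compound 2 in one place: 3-methoxyphenyl in place of 2-methoxyphenyl on an amine nitrogen. Among the measured compounds shown here, only one measured step exists, and it concerns methoxy in place of hydrogen rather than the exchange of 2-methoxyphenyl for 3-methoxyphenyl; it stayed within the scatter. For the measured compounds named here, no measured pair shows what this particular exchange does. With only that to go on, the expected step from compound 2 to compound 3 is a 1.0-fold higher number from compound 2 to compound 3 (0.01 log units; within the scatter), none beyond the scatter. Compound 3 is therefore estimated at 1700 nM, with a range from 800 nM to 3600 nM.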

Compound 3, half-maximal inhibitory concentration: 1790 nM
For compound 3 the middle estimate is 1.1-fold (0.02 log units) below the measured one, within the range that was stated.
By their numbers in this assay, from the lowest: compounds 2, 3 and 1 (each within the scatter of the next).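

The exchange of 2-methoxyphenyl for 3-methoxyphenyl on the amine nitrogen now has a direct reading in this assay: there is a 1.1-fold higher number from compound 2 to compound 3 (0.03 log units; within the scatter). Among these compounds, the earlier compounds showed only that adding a methoxy group to the phenyl ring in one place left the number within the scatter, and the same now holds for the second place, with a 1.0-fold lower number from compound 1 to compound 3 (0.01 log units; within the scatter). Across these three compounds, then, neither the presence of the methoxy group nor the choice between these two placements separates one compound from another in this assay, and no other data on these compounds are available to interpret that result.

From the compounds shown here alone, whether a different group on the phenyl ring, such as a carboxylic acid, a dimethylamino group or the longer ethoxy chain, would move the number beyond the scatter remains open. Also open, going by these compounds, is how much changes elsewhere on the molecule would matter, since all three compounds share the same core and differ only in the group on the amine nitrogen.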